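From piperazin-1-yl to 3,5-dimethylpiperazin-1-yl: cytotoxicity notes

The compounds below may be only part of what the source reports. "The series", "measured", "known", "first", "only" and "open" are said of these compounds alone.

Values in a functional assay on V79 cells (Cricetulus griseus) for cytotoxicity, read by colony formation; on this read-out higher numbers stand for weaker inhibition and lower numbers for stronger inhibition:
compound 1 `O=C(O)c1cn(C2CC2)c2c(F)c(N3CCCC3)c(F)cc2c1=O`: 120 ug/mL
compound 2 `O=C(O)c1cn(C2CC2)c2c(F)c(N3CCNCC3)c(F)cc2c1=O`: 47 ug/mL

Of the two measured compounds, compound 2 at 47 ug/mL has the lower number, and so the stronger inhibition on this read-out. The next structure is compound 3 `CC1CN(c2c(F)cc3c(=O)c(C(=O)O)cn(C4CC4)c3c2F)CC(C)N1`, and the change is 3,5-dimethylpiperazin-1-yl in place of piperazin-1-yl on an aromatic carbon, ortho to two fluoro groups.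

Among the compounds with values here, only one measured step bears on this place: a 2.6-fold lower number from compound 1 to compound 2 (0.41 log units; beyond the scatter), a modest step. Within the data shown here, it exchanges pyrrolidin-1-yl for piperazin-1-yl, so it is a different change, and no measured compound carries the 3,5-dimethylpiperazin-1-yl group. It offers a rough ceiling on size but no direction. The expectation therefore stays close to compound 2 at 47 ug/mL and leans only slightly lower. The expected outcome in this assay is a 1.2-fold lower number from compound 2 to compound 3 (0.07 log units; within the scatter), which means no step beyond the scatter is expected. For compound 3 the estimate is 40 ug/mL, with an expected range of 16 ug/mL to 100 ug/mL in this series.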

Compound 3, half-maximal inhibitory concentration: 150 ug/mL
Beside the measured number, compound 3's estimate is 3.8-fold (0.57 log units) below it, and the stated range ends below it.
By their numbers in this assay, from the lowest: compound 2; then compounds 1 and 3 (each within the scatter of the next).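

In this assay, 3,5-dimethylpiperazin-1-yl in place of piperazin-1-yl gives a clear move toward weaker inhibition (a 3.2-fold higher number from compound 2 to compound 3 (0.50 log units; beyond the scatter)), so this aromatic carbon, ortho to two fluoro groups, responds to substitution on the piperazine ring itself and not only to an exchange of one ring for another. Set against pyrrolidin-1-yl, the 3,5-dimethylpiperazin-1-yl group cannot be told apart (a 1.3-fold higher number from compound 1 to compound 3 (0.10 log units; within the scatter)), which leaves the unsubstituted piperazin-1-yl of compound 2 alone at the stronger end of these three compounds and shows that the piperazine ring as such does not carry the lower number once it bears these methyl groups. Nothing available here accounts for the shift seen with the 3,5-dimethylpiperazin-1-yl group.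

On these data alone, whether 3-methylpiperazin-1-yl would stand with compound 2 or with compound 3 remains open, and so does the placing of 4-methylpiperazin-1-yl, with its methyl group on the ring nitrogen. Also open, as far as these compounds go, is how a pyrrolidine ring bearing an amine, such as 3-aminopyrrolidin-1-yl, would read at this same position on the shared core.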